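Replacing the chlorophenyl group on the ring nitrogen

A few compounds are considered here, and "the series" means these few. Any claim that something is new, unique, unknown or untested is made for them only; others in the source may bear on it.

Measured so far:
Compound 1, `CC(C)(C)C1=NN(c2cccc(Cl)c2)C(c2ccc(O)cc2)C1`: 96.8%
Compound 2, `CC(C)(C)C1=NN(c2cccc(F)c2)C(c2ccc(O)cc2)C1`: 98.1%
Compound 3, `CC(C)(C)C1=NN(c2ccccc2Cl)C(c2ccc(O)cc2)C1`: 57.1%

In an assay on isolated protein for inhibition of protein kinase C zeta type (Homo sapiens), with a stated time of 4 min, tested at 62.5 uM (a lower number here means less inhibition, a higher number more inhibition at the concentration tested (going by the name of the read-out)), compound 3 has the lowest of the three numbers. Compound 1 and compound 2 sit close together, and the step of a number 1.3 percentage points higher from compound 1 to compound 2 (within the scatter) lies within the scatter. The two steps leading to compound 3 are large: a number 39.7 percentage points lower from compound 1 to compound 3 (beyond the scatter) and a number 41 percentage points lower from compound 2 to compound 3 (beyond the scatter). Both describe the same kind of change, a move of the halogen on the phenyl group attached to the ring nitrogen, and both cost a large share of the inhibition.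

Compound 4, `CC(C)(C)C1=NN(c2ccc(O)cc2)C(c2ccc(O)cc2)C1`, differs from compound 3 in one place: 4-hydroxyphenyl in place of 2-chlorophenyl on an amine nitrogen in a ring. Among the compounds with values here, no measured step covers a 4-hydroxyphenyl group at this position, so the direction of the step must be judged from the pattern of compounds 1, 2 and 3 alone. Those show that a 2-chlorophenyl group gives weaker inhibition than a 3-halophenyl group. Compound 4 leaves the 2-chlorophenyl group behind and carries a group more like those of compound 1 and compound 2, though not identical. A step upward in this assay is therefore expected for compound 4, of about a number 27.9 percentage points higher from compound 3 to compound 4 (beyond the scatter), with considerable uncertainty because no direct comparison exists. Compound 4 is estimated at 85%, ranging from 55% to 100%.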

Compound 4, a percentage reported as inhibition, at one concentration (the size of the read-out at that concentration, not a potency): 40.9%
Compound 4: the middle estimate sits 44.1 percentage points above what was measured; measured number outside the range, below it.
By their numbers in this assay, from the lowest: compound 4; then compound 3; then compounds 1 and 2 (each within the scatter of the next).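

In this assay, within the data shown here, the earlier compounds showed only that moving a halogen around the phenyl group on the ring nitrogen changes the result, and the 4-hydroxyphenyl group now falls below all three halogen-bearing groups. Against the 2-chlorophenyl group the change is modest, a number 16.2 percentage points lower from compound 3 to compound 4 (beyond the scatter), whereas against the two groups that gave the most inhibition it is large, a number 57.2 percentage points lower from compound 2 to compound 4 (beyond the scatter) and a number 55.9 percentage points lower from compound 1 to compound 4 (beyond the scatter), so the 2-chlorophenyl group of compound 3 is not the low end of this position. Nothing measured here gives a reason for this loss of inhibition.

The compounds shown do not separate the hydroxy group from its place on the phenyl group, as none carries a halogen at that place or a hydroxy group at another. They also leave open how a methoxy group or an amine would compare with that hydroxy group, and how an unsubstituted phenyl group would compare with all of these.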